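Thiophen-2-yl for 4-methylphenyl on the sulfonyl sulfur

The source may hold more compounds than are shown below. What is called first, only, known or untested is meant among the compounds shown, and "the series" means these compounds.

In a functional assay on MDA-MB-231 cells (Homo sapiens) for antiproliferative activity, read by sulforhodamine B assay, with a stated time of 72 h (a higher number here means a weaker inhibitor, a lower number a stronger inhibitor), compound 1 (`CC(C)C[C@H](NC(=O)CSc1cc(NS(=O)(=O)c2ccc(Cl)cc2)c2ccccc2c1O)B(O)O`) gives 6190 nM, compound 2 (`CC(C)C[C@H](NC(=O)CSc1cc(NS(=O)(=O)c2cccs2)c2ccccc2c1O)B(O)O`) gives 6520 nM and compound 3 (`Cc1ccc(S(=O)(=O)Nc2cc(SCCC(=O)N[C@@H](CC(C)C)B(O)O)c(O)c3ccccc23)cc1`) gives 6150 nM. These three values lie within the scatter of one another, so compound 3 stands level with the other two and no order can be read among them.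

Compound 4 (`CC(C)C[C@H](NC(=O)CCSc1cc(NS(=O)(=O)c2cccs2)c2ccccc2c1O)B(O)O`) has thiophen-2-yl in place of 4-methylphenyl on a sulfonyl sulfur.

Among the measured compounds shown here, only one measured step bears on this change. It brings in the same thiophen-2-yl, there in place of 4-chlorophenyl, and gives a 1.1-fold higher number from compound 1 to compound 2 (0.02 log units; within the scatter), which is within the scatter. For the measured compounds named here, no measured step starts from 4-methylphenyl, so this support is indirect and rests on a single pair.

In this assay, the expected result is therefore no step beyond the scatter, with the estimated step being a 1.0-fold higher number from compound 3 to compound 4 (0.01 log units; within the scatter). For compound 4 the estimated value is 6300 nM, with an expected range of 3500 nM to 11000 nM.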

Compound 4, half-maximal inhibitory concentration: 4450 nM
For compound 4 the middle estimate is 1.4-fold (0.15 log units) above the measured one; the range from low to high includes it.
By their numbers in this assay, from the lowest: compounds 4, 3, 1 and 2 (each within the scatter of the next).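

In this assay, the exchange of 4-methylphenyl for thiophen-2-yl on the sulfonyl sulfur now has its own direct measurement, a 1.4-fold lower number from compound 3 to compound 4 (0.14 log units; within the scatter). Together with a 1.1-fold higher number from compound 1 to compound 2 (0.02 log units; within the scatter), this means thiophen-2-yl has been read against two different aryl partners at this position, in two compounds that differ elsewhere, and neither step goes beyond the scatter. No measurement is available that could explain either step.

Across these four compounds, the position has seen only thiophen-2-yl, 4-chlorophenyl and 4-methylphenyl, all aromatic rings without a charge. On these data alone, whether a group of another kind on the sulfonyl sulfur, such as a phenyl ring carrying a carboxylic acid or an amine, or an open alkyl chain, would move the number beyond the scatter remains open.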